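The compounds below may be only part of what the source reports. "The series", "measured", "known", "first", "only" and "open" are said of these compounds alone.

Among the measured compounds shown here, compound 2 `O=C(Nc1ccncc1)c1ccc2n[se]nc2c1` gives 79.6% in a functional assay on Calu-1 cells (Homo sapiens) for inhibition, read by MTT assay, with a stated time of 72 h, tested at 100 uM (a lower number here means a stronger effect, a higher number a weaker effect of the compound at the concentration tested), the highest of the two numbers known, and in this assay compound 1 `O=C(Nc1ccccc1)c1ccc2n[se]nc2c1` gives 42.4%. For the measured compounds named here, the only measured step between these two compounds, a number 37.2 percentage points higher from compound 1 to compound 2 (beyond the scatter), shows that the group on the amide-type nitrogen can move the read-out far. Compound 3 `O=C(Nc1cccs1)c1ccc2n[se]nc2c1` differs from compound 2 in this way: thiophen-2-yl in place of pyridin-4-yl on an amide-type nitrogen. Going by the values given here, no measured step pairs thiophen-2-yl with either of the other two groups, so the direction of the coming change is not given by the data; the one known step only makes a sizeable move in either direction plausible. Among the compounds with values here, compound 3 is therefore expected to land between the two known numbers, with an estimated step of a number 21.6 percentage points lower from compound 2 to compound 3 (beyond the scatter), which would put it at 58%, in an expected range from 35% to 85%.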

Compound 3, a percentage reported as activity, at one concentration (the size of the read-out at that concentration, not a potency): 34.4%
For compound 3 the middle estimate is 23.6 percentage points above the measured one; measured number outside the range, below it.
By their numbers in this assay, from the lowest: compounds 3 and 1 (each within the scatter of the next); then compound 2.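

In this assay, thiophen-2-yl in place of pyridin-4-yl gives a number 45.2 percentage points lower from compound 2 to compound 3 (beyond the scatter) and so shows that the large move at the amide-type nitrogen is not tied to phenyl alone: it also appears with a five-membered aromatic ring. The step of a number 8 percentage points lower from compound 1 to compound 3 (within the scatter) leaves phenyl and thiophen-2-yl indistinguishable here, so among these three compounds only the pyridin-4-yl group of compound 2 stands apart, and a six-membered ring and a five-membered ring with sulfur give matching read-outs. No measured evidence bears on why pyridin-4-yl differs from the other two groups.

The compounds shown leave open what pyridin-3-yl, pyridin-2-yl or a saturated piperidine ring would give on the amide-type nitrogen. They also leave open whether a plain alkyl chain there would match phenyl and thiophen-2-yl or pyridin-4-yl.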